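Swapping a Cyclopentyl for a Triazole: Expected Solubility

A few compounds are considered here, and "the series" means these few. Any claim that something is new, unique, unknown or untested is made for them only; others in the source may bear on it.

Compound 1 `CC(C)c1ncc2c(N)c(C#N)c(N)nc2n1` in a physicochemical assay for solubility, in phosphate buffer, with a stated time of 18 h (a higher number here means a more soluble compound, a lower number a less soluble compound), gives > 1000000 nM, which is a limit of the assay rather than a number. Compound 2 `CC(C)(C)c1nc(C2CCCC2)c2c(N)c(C#N)c(N)nc2n1` gives < 1000 nM in this assay, again only a limit. Compound 2 therefore stands at the lower of the two limits shown (the limit of < 1000 nM in this assay, at which 1 of the 2 values shown sits), while compound 1 sits at the other (the limit of > 1000000 nM in this assay, at which 1 of the 2 values shown sits). Compound 3 `CC(C)(C)c1nc(-c2ncn[nH]2)c2c(N)c(C#N)c(N)nc2n1` has not yet been measured; it differs from compound 2 by 1H-1,2,4-triazol-5-yl in place of cyclopentyl on an aromatic carbon. This change is expected to raise solubility in this assay, by an estimated at least 20-fold higher number from compound 2 to compound 3 (1.30 log units; beyond the scatter). Compound 3 is accordingly estimated at 20000 nM, within a range from 2000 nM to 200000 nM.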

Compound 3, solubility: 64500 nM
Estimate against measurement, compound 3: 3.2-fold (0.51 log units) below; low and high end bracket the measured number.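

In this assay, 1H-1,2,4-triazol-5-yl in place of cyclopentyl on this aromatic carbon, next to the ring nitrogen, gives an at least 64-fold higher number from compound 2 to compound 3 (1.80 log units; beyond the scatter), so this position can carry a large change in the read-out. Both groups hold the same number of heavy atoms, so this step involves no larger group. Compound 2 gives only a limit of the assay, not a number: the limit of < 1000 nM in this assay, at which 1 of the 3 values shown sits. Still open, from the compounds shown here alone, is whether an amine or a carboxylic acid at this position would give a similar number.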